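Chloroquinoline hydrazone series: pyrrole in place of dimethyl-isoxazole

The compounds below may be only part of what the source reports. "The series", "measured", "known", "first", "only" and "open" are said of these compounds alone.

Measured so far:
- compound 1 `Cc1noc(C)c1/C=N/Nc1ccnc2cc(Cl)ccc12`: 171 uM
- compound 2 `FC(F)(F)c1ccc(-c2n[nH]cc2/C=N/Nc2ccnc3cc(Cl)ccc23)cc1`: 1.2 uM
- compound 3 `Clc1ccc2c(N/N=C/c3ccc(CN4CCCC4)cc3)ccnc2c1`: 19.5 uM

All three share the same core and differ only in the group carried on the carbon of the hydrazone. In a functional assay on KB cells (Homo sapiens) for cytotoxicity (a higher number here means that more compound is needed for the effect, a lower number that less compound is needed), compound 1 gives 171 uM, the highest number of the three. Compound 3 sits nearest to it in this assay with 19.5 uM, a gap well beyond the scatter, and compound 2 lies furthest away with 1.2 uM. Both the aryl-bearing compounds thus need far less compound for the half-maximal effect than compound 1.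

Compound 4 `Clc1ccc2c(N/N=C/c3ccc[nH]3)ccnc2c1` is not yet measured. Relative to compound 1 the change is 1H-pyrrol-2-yl in place of 3,5-dimethyl-1,2-oxazol-4-yl on a carbon with a double bond to nitrogen. Going by the values given here, no directly comparable pair has been measured, so the size of the step is open. Given that every comparison available places compound 1 at the weak end, with compound 3 at 19.5 uM and compound 2 at 1.2 uM, the expectation is that the move to a five-membered aromatic ring with one hetero atom will lower the number, by a moderate step beyond the scatter rather than a dramatic one.

For compound 4 the expected value in this assay is 45 uM, estimated to fall between 12 uM and 170 uM. This corresponds to an expected step of a 3.8-fold lower number from compound 1 to compound 4 (0.58 log units; beyond the scatter).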

Compound 4, concentration for half-maximal effect: 4.8 uM
Compound 4: the middle estimate sits 9.4-fold (0.97 log units) above what was measured, outside the stated range (below it).
By their numbers in this assay, from the lowest: compound 2; then compound 4; then compound 3; then compound 1.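

In this assay, going by these compounds alone, 1H-pyrrol-2-yl in place of 3,5-dimethyl-1,2-oxazol-4-yl on a carbon with a double bond to nitrogen gives a 36-fold lower number from compound 1 to compound 4 (1.55 log units; beyond the scatter) and provides the first step that can be read directly for this position. The earlier compounds shown here left open whether a large group such as those in compound 2 and compound 3 was needed for a low number, yet compound 4 with its unsubstituted five-membered ring stands at 4.8 uM while compound 3 stands at 19.5 uM in the same assay. Nothing available accounts for the step, and this single pair changes the heavy-atom count, the hetero atoms, and the hydrogen-bond donors and acceptors all at once.

Still open, as far as these compounds go, is which of these differences carries the step, and a 1-methylpyrrol-2-yl or a furan-2-yl group at the same place would help separate the hydrogen-bond donor of the pyrrole from the ring itself. From the compounds shown here alone, it is also open whether methyl groups on the pyrrole ring would move the number back towards that of compound 1.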